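This account rests on a few compounds, and the source may have more. Where it says the series, first, only, none or still open, it means among the compounds named here.

Measured in a physicochemical assay for solubility, read by nephelometry, measured as kinetic solubility, at pH 2; a lower number here means a less soluble compound, a higher number a more soluble compound:
Compound 1 `O=C(NNS(=O)(=O)c1ccccc1F)c1cc(F)cc(-n2cccn2)c1`: 25 ug/mL
Compound 2 `Cc1cc(C(=O)NNS(=O)(=O)c2ccccc2F)cc(-n2cccn2)c1`: 12.5 ug/mL
Compound 3 `Cc1cc(-c2ncccn2)cc(C(=O)NNS(=O)(=O)c2ccccc2)c1F`: 50 ug/mL

Compound 3 lies within the scatter of compound 1 and stands beyond the scatter from compound 2. Compound 4 `Cc1cc(-n2cccn2)cc(C(=O)NNS(=O)(=O)c2ccccc2)c1F` carries 1H-pyrazol-1-yl in place of pyrimidin-2-yl on an aromatic carbon. Going by the values given here, no measured step makes this exchange. Among the compounds with values here, the only step available, methyl in place of fluoro on an aromatic carbon, is a different change and stays within the scatter: a 2.0-fold lower number from compound 1 to compound 2 (0.30 log units; within the scatter). Compound 1 and compound 2 carry 1H-pyrazol-1-yl but also differ from compound 3 elsewhere, so they offer only a weak hint. With compound 1 at 25 ug/mL and compound 2 at 12.5 ug/mL, a small drop in this assay is expected, near the edge of the scatter. The expected change is a 2.0-fold lower number from compound 3 to compound 4 (0.30 log units; within the scatter). For compound 4 the estimated value is 25 ug/mL, with an expected range of 10 ug/mL to 60 ug/mL.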

Compound 4, solubility: 6.3 ug/mL
Compound 4: the middle estimate sits 4.0-fold (0.60 log units) above what was measured, and the stated range ends above it.
By their numbers in this assay, from the lowest: compounds 4, 2, 1 and 3 (each within the scatter of the next, the first and the last beyond it).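

In this assay, going by these compounds alone, the exchange of pyrimidin-2-yl for 1H-pyrazol-1-yl on this aromatic carbon, para to a fluoro group, can now be read directly: it gives a 7.9-fold lower number from compound 3 to compound 4 (0.90 log units; beyond the scatter) and so lies beyond the scatter, unlike the only earlier step, a different change. The position therefore responds to this exchange, at least on this core. Nothing at hand accounts for the step.

As far as these compounds go, whether the step holds on the core of compound 1 stays open. So does what pyridin-2-yl or an amine would give at this position.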